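From Dimethylphenyl to Trifluoromethylphenyl on the Shared Core

The source may report more compounds than this note shows. Statements on the series, on what has been measured and on what is new or still open speak of the compounds shown alone.

For the measured compounds named here, compound 1 `Cc1ccc(NC2=CC(=O)c3c(nc4n3[C@H]3OC[C@@H](O)[C@H]3OC4)C2=O)cc1C` gives 1050 nM in a functional assay on MGC-803 cells (Homo sapiens) for inhibition, read by sulforhodamine B assay (on this read-out higher numbers stand for weaker inhibition and lower numbers for stronger inhibition), the lowest of the two numbers measured so far. Compound 3 `CCOc1ccccc1NC1=CC(=O)c2nc3n(c2C1=O)[C@H]1OC[C@@H](O)[C@H]1OC3` gives 2450 nM in this assay. For compound 2 `O=C1C=C(NC2CCCCC2)C(=O)c2c1nc1n2[C@H]2OC[C@@H](O)[C@H]2OC1` only a limit is known in this assay, namely > 8000 nM. Going by the values given here, the one measured step, an at least 3.2-fold lower number from compound 2 to compound 3 (0.51 log units; beyond the scatter), favours an aromatic ring on the amine nitrogen over cyclohexyl, and the limit of > 8000 nM in this assay, at which 1 of the 3 values shown sits, makes its size a bound rather than a number. Compound 4 `O=C1C(Nc2ccc(C(F)(F)F)cc2)=CC(=O)c2c1nc1n2[C@H]2OC[C@@H](O)[C@H]2OC1` differs from compound 1 by 4-(trifluoromethyl)phenyl in place of 3,4-dimethylphenyl on an amine nitrogen. Among the compounds with values here, both groups are aromatic rings, so no measured step bears directly on this change, and no step beyond the scatter is expected. Compound 4 is estimated at 1500 nM, within 600 nM to 4000 nM in this assay. The step expected is a 1.4-fold higher number from compound 1 to compound 4 (0.15 log units; within the scatter).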

Compound 4, half-maximal inhibitory concentration: 1860 nM
Compound 4: the middle estimate sits 1.2-fold (0.09 log units) below what was measured; the range from low to high includes it.
By their numbers in this assay, from the lowest: compounds 1, 4 and 3 (each within the scatter of the next, the first and the last beyond it). At a limit, above all of these: compound 2.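

Replacing 3,4-dimethylphenyl with 4-(trifluoromethyl)phenyl on the amine nitrogen gives a 1.8-fold higher number from compound 1 to compound 4 (0.25 log units; within the scatter) in this assay and is the first step shown between two aromatic rings at this position. Within this pair, the position accepts either group without a change beyond the scatter, whereas the earlier step compared an aromatic ring only with cyclohexyl. Nothing shown explains this small step.

As far as these compounds go, it remains open how a phenyl ring carrying an amine or a carboxylic acid would behave on this nitrogen. The same is true of a longer chain placed between the nitrogen and the ring.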